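A few compounds are considered here, and "the series" means these few. Any claim that something is new, unique, unknown or untested is made for them only; others in the source may bear on it.

Compound 1, `NC(=O)[C@@H](c1ccccc1)N(C(=O)c1ccccc1)[C@@H]1CCc2c(F)cc(Cl)cc21`: 300 nM
Compound 2, `NC(=O)[C@@H](c1ccccc1)N(C(=O)c1cccnc1)[C@@H]1CCc2c(F)cc(F)cc21`: 110 nM

Both compounds were tested in an assay on HEK293T cells for antagonist activity at transient receptor potential cation channel subfamily M member 8 (Homo sapiens), read by fluorescence and calcium flux, with a stated time of 60 min; on this read-out higher numbers stand for weaker inhibition and lower numbers for stronger inhibition. Of the two numbers, compound 2 has the lower one; compound 1 stands higher, a gap beyond the usual scatter. The two structures differ in two places at once, so no single-change step can be read from them.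

Compound 3, `NC(=O)[C@@H](c1ccccc1)N(C(=O)c1cccnc1)[C@@H]1CCc2c(F)cc(Cl)cc21`, differs from compound 2 in one place only: chloro in place of fluoro on an aromatic carbon. Compound 3 also shares its chloro group with compound 1, while keeping the pyridinyl amide of compound 2. For the measured compounds named here, no measured pair shows this exchange by itself, so the expected step from compound 2 to compound 3 is small, a 1.5-fold higher number from compound 2 to compound 3 (0.16 log units; within the scatter), and may well stay within the scatter. Compound 3 is therefore estimated at 160 nM, with a likely range from 60 nM to 420 nM.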

Compound 3, half-maximal inhibitory concentration: 110 nM
For compound 3 the middle estimate is 1.5-fold (0.16 log units) above the measured one; the measured number falls inside the stated range.
By their numbers in this assay, from the lowest: compounds 2 and 3 (each within the scatter of the next); then compound 1.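

In this assay, chloro in place of fluoro on this aromatic carbon, meta to a fluoro group, gives no change at the digits printed from compound 2 to compound 3 (within the scatter) when the pyridin-3-yl amide is present, so here the two halogens cannot be told apart. Pyridin-3-yl in place of phenyl on the carbonyl carbon, with the chloro group kept, gives a 2.7-fold lower number from compound 1 to compound 3 (0.44 log units; beyond the scatter) and is the only one of these two single changes to move the number beyond the scatter. No measurement here explains either result.

As far as these compounds go, it remains open whether a larger group on this aromatic carbon, such as methyl or methoxy, would also leave the number in place. From the compounds shown here alone, it is equally open whether the halogen exchange would read the same with phenyl on the carbonyl carbon, and whether pyridin-2-yl there would match pyridin-3-yl.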